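The source may hold more compounds than are shown below. What is called first, only, known or untested is meant among the compounds shown, and "the series" means these compounds.

Measured so far in a toxicity assay on MDCK cells (Canis lupus familiaris) for cytotoxicity, read by crystal violet staining, with a stated time of 48 h; a higher number here means that more compound is tolerated, a lower number that less compound is tolerated:
Compound 1 `Cc1ccc2[nH]c(=O)c(CN(Cc3ccc(O)cc3)Cc3ccc(C(C)(C)C)cc3)cc2c1` gives 4900 nM.
Compound 2 `CCCOc1ccc(CN(Cc2ccc(C(C)(C)C)cc2)Cc2cc3cc(C)ccc3[nH]c2=O)cc1` gives > 5000 nM, a limit of the assay.
Compound 3 `CCCCOc1ccc(CN(Cc2ccc(C(C)(C)C)cc2)Cc2cc3cc(C)ccc3[nH]c2=O)cc1` gives > 5000 nM, also a limit of the assay.

Compound 3 therefore stands only at the limit of > 5000 nM in this assay, at which 2 of the 3 values shown sit, with no number of its own. The step to compound 4 `Cc1ccc2[nH]c(=O)c(CN(Cc3ccc(C(N)=O)cc3)Cc3ccc(C(C)(C)C)cc3)cc2c1` is carbamoyl in place of butoxy on an aromatic carbon. For the measured compounds named here, no measured step covers this exact change; the nearest are an at least 1.0-fold higher number from compound 1 to compound 3 (0.00 log units; that floor lies within the scatter) and an at least 1.0-fold higher number from compound 1 to compound 2 (0.00 log units; that floor lies within the scatter), both floors that lie within the scatter, and a step that the two limits leave unreadable from compound 2 to compound 3. With every measured value at or close to the limit, no step beyond the scatter is expected in this assay, and a number no higher from compound 3 to compound 4 (the limit leaves the size open) is the estimated step. Compound 4 is expected at 5000 nM, in the range 2500 nM to 10000 nM, and may again be reported only as a limit.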

Compound 4, half-maximal cytotoxic concentration: > 5000 nM
Compound 4 gave a limit, no number (the forecaster's own chance of this, stated with the estimate: 55%); the middle value lies on the limit itself.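

In this assay compound 4, with carbamoyl on the aromatic carbon para to a large group, gives > 5000 nM, a limit of the assay. Set against the hydroxy group, this change gives an at least 1.0-fold higher number from compound 1 to compound 4 (0.00 log units; that floor lies within the scatter), while the steps from compound 2 and compound 3 to compound 4 cannot be read. Carbamoyl thus joins propoxy and butoxy at this position without a readable change, so the series now rests mostly on one limit: the limit of > 5000 nM in this assay, at which 3 of the 4 values shown sit.

As far as these compounds go, whether an amine or a carboxylic acid on this carbon would give a number under the limit stays open. From the compounds shown here alone, how far compound 2, compound 3 and compound 4 lie beyond the limit also stays open.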